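A few compounds are considered here, and "the series" means these few. Any claim that something is new, unique, unknown or untested is made for them only; others in the source may bear on it.

In an ADME assay on microsomes from liver (Homo sapiens) for metabolic stability (on this read-out lower numbers stand for slow clearance and higher numbers for fast clearance), three compounds have been measured so far. Compound 1 (`Cc1ccc(C(=O)Nc2cc3nncn3c(CN3CCN(C(=O)C4CCCC4)[C@@H](C)C3)c2C)cn1`) gives 59 mL.min-1.g-1, compound 2 (`Cc1ccc(C(=O)Nc2cn3ncnc3c(O[C@@H]3CCN(C(=O)CC(C(F)(F)F)C(F)(F)F)[C@@H](C)C3)c2C)cn1`) gives 28 mL.min-1.g-1, and compound 3 (`Cc1ccc(C(=O)Nc2cn3ncnc3c(CN3CCN(C(=O)C(C)C)[C@@H](C)C3)c2C)cn1`) gives 240 mL.min-1.g-1. Compound 3 therefore has the highest number of the three, and its gaps to both of the others lie beyond the usual scatter of repeated measurements.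

The next compound, compound 4 (`Cc1ccc(C(=O)Nc2cn3ncnc3c(CN3CCN(C(=O)C4CCOCC4)[C@@H](C)C3)c2C)cn1`), differs from compound 3 in one place: oxan-4-yl in place of isopropyl on a carbonyl carbon. In plain terms, oxan-4-yl stands in place of isopropyl on a carbonyl carbon, and the rest of the structure is unchanged.

Among the measured compounds shown here, no two measured compounds differ in only one place, so the data offer no direct precedent for this change, and any forecast is uncertain. The expectation rests on where compound 3 stands: at 240 mL.min-1.g-1 it is at the top of the measured range, while compound 1 at 59 mL.min-1.g-1 shows a far lower number in a related structure. A fall therefore seems more likely than a rise. The expected step, a 2.4-fold lower number from compound 3 to compound 4 (0.38 log units; beyond the scatter), is downward and modest, slightly beyond the scatter. For compound 4 the estimated value in this assay is 100 mL.min-1.g-1, with an expected range from 45 mL.min-1.g-1 to 210 mL.min-1.g-1.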

Compound 4, intrinsic clearance in microsomes: < 10 mL.min-1.g-1
Compound 4 ended at the assay's limit (the forecaster's own chance of this, stated with the estimate: 3%); middle value at least 10-fold (1.00 log units) from the limit.
By their numbers in this assay, from the lowest: compound 2; then compound 1; then compound 3. At a limit, below all of these: compound 4.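

In this assay, among the compounds shown here, oxan-4-yl in place of isopropyl on a carbonyl carbon gives an at least 24-fold lower number from compound 3 to compound 4 (1.38 log units; beyond the scatter), the first step in this set that isolates a single place, and it shows that a change on this carbonyl carbon alone can move the read-out by a large amount. Compound 4 reads < 10 mL.min-1.g-1, which is a limit of the assay and not a number. The step is therefore bounded on one side only, and the true value of compound 4 cannot be placed: the limit of < 10 mL.min-1.g-1 in this assay, at which 1 of the 4 values shown sits.

The compounds shown leave open whether the step belongs to the ring oxygen of oxan-4-yl or to the six-membered ring as such; a cyclohexyl group on the same carbonyl carbon would separate the two. Also open, on these data alone, is whether the same change would act alike on the structures of compound 1 and compound 2, which differ from compound 3 in more than one place.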